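The source may report more compounds than this note shows. Statements on the series, on what has been measured and on what is new or still open speak of the compounds shown alone.

Measured compounds:
compound 1 `Cc1ccc(-c2nn(-c3ccccc3)cc2C(=O)NOCc2ccccc2)cc1`, 1870 nM
compound 2 `Cc1ccc(-c2nn(-c3ccccc3)cc2C(=O)NOCc2ccc(Cl)cc2Cl)cc1`, 2310 nM

Both compounds were tested in a functional assay on MCF7 cells (Homo sapiens) for antiproliferative activity, read by MTT assay, with a stated time of 48 h, in the presence of a further agent that is not named here; a higher number here means a weaker inhibitor of growth, a lower number a stronger inhibitor of growth. Among the compounds with values here, compound 2 gives the higher of the two numbers, but the only measured step, a 1.2-fold higher number from compound 1 to compound 2 (0.09 log units; within the scatter), is within the scatter, so the two compounds cannot be told apart on these data.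

Compound 3 `O=C(NOCc1ccc(Cl)cc1Cl)c1cn(-c2ccccc2)nc1-c1ccc(F)cc1` has not been measured. It differs from compound 2 in one place: fluoro in place of methyl on an aromatic carbon. Within the data shown here, no measured step bears on this change. Among the measured compounds shown here, the single step known, a 1.2-fold higher number from compound 1 to compound 2 (0.09 log units; within the scatter), concerns the other end of the molecule and says nothing about the ring that is altered here. With no evidence for a shift in either direction, no change beyond the scatter is expected in this assay.

Compound 3 is therefore estimated to give 2500 nM, with a range from 1000 nM to 6500 nM. The step this estimate implies, a 1.1-fold higher number from compound 2 to compound 3 (0.03 log units; within the scatter), is expected to stay within the scatter.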

Compound 3, concentration for 50% growth inhibition: 25300 nM
For compound 3 the middle estimate is 10-fold (1.01 log units) below the measured one; measured number outside the range, above it.
By their numbers in this assay, from the lowest: compounds 1 and 2 (each within the scatter of the next); then compound 3.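

Replacing the methyl of the 4-methylphenyl group with fluoro exchanges one heavy atom for one heavy atom, with no change in the count of hydrogen-bond donors or acceptors, yet in this assay it gives an 11-fold higher number from compound 2 to compound 3 (1.04 log units; beyond the scatter) and a clearly weaker inhibitor of growth. This place on the aromatic ring, para to a large group, therefore matters for growth inhibition in these compounds. The earlier step, a 1.2-fold higher number from compound 1 to compound 2 (0.09 log units; within the scatter), involved a change at the other end of the molecule and stayed within the scatter, so it gave no sign of this sensitivity. Nothing available explains the size of this step.

The compounds shown leave open whether the methyl itself is needed or the fluoro is what does harm, which a hydrogen, chloro, ethyl or methoxy group at this place could help to separate. They also leave open whether the same change would have a similar effect with the unsubstituted benzyl group of compound 1.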